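The compounds below may be only part of what the source reports. "The series", "measured", "known", "first", "only" and "open" are said of these compounds alone.

Three compounds share a core built from a chromone with a substituted piperidine attached, and they were tested in a functional assay on Caco-2 cells (Homo sapiens) for inhibition, read by MTT assay, with a stated time of 48 h, tested at 10 uM; a higher number here means more inhibition of growth at the concentration tested, a lower number less inhibition of growth. Compound 1 `Cc1oc2c([C@H]3CCN(C)C[C@H]3O)c(O)cc(O)c2c(=O)c1C(O)c1cccc(Cl)c1` gives 4% in this assay. Compound 2 `Cc1oc2c([C@H]3CCN(C)C[C@H]3O)c(O)cc(O)c2c(=O)c1C(O)c1cccc(Cl)c1Cl` gives 3% in this assay. The two differ in one place, where (chloro in place of hydrogen on an aromatic carbon); the step of a number 1 percentage points lower from compound 1 to compound 2 (within the scatter) lies within the scatter, so the two numbers cannot be told apart.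

Compound 3 `CN1CC[C@H](c2c(O)cc(O)c3c(=O)cc(/C=C/c4ccccc4)oc23)[C@H](O)C1` carries a different side group on the core, and the difference between the two cores is not broken down here. In this assay compound 3 gives 72%, the highest of the three numbers, with the other two lying beyond the scatter below it.

Compound 4 `CN1CC[C@H](c2c(O)cc(O)c3c(=O)cc(/C=C/c4ccc(Cl)cc4)oc23)[C@H](O)C1` has not yet been measured. It is made from compound 3 by chloro in place of hydrogen on an aromatic carbon. Within the data shown here, this is the same kind of change as the one from compound 1 to compound 2, not the same change: in compound 2 the entering chloro sits ortho to a chloro group and ortho to a large group, while in compound 4 it sits para to a large group. Because a number 1 percentage points lower from compound 1 to compound 2 (within the scatter) stayed within the scatter, the step from compound 3 to compound 4 is expected to be small as well, roughly a number 2 percentage points lower from compound 3 to compound 4 (within the scatter). For compound 4 the expected value in this assay is therefore 70%, likely lying between 50% and 88%.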

Compound 4, percent growth inhibition at one concentration: 70%
Estimate against measurement, compound 4: no gap at the digits printed; low and high end bracket the measured number.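

In this assay, the new step is a number 2 percentage points lower from compound 3 to compound 4 (within the scatter), so the numbers for these two compounds cannot be told apart. Set beside the earlier step, the change from hydrogen to chloro on an aromatic carbon looks the same on both cores: the same change on two cores in this assay, a number 1 percentage points lower (within the scatter) from compound 1 to compound 2 and a number 2 percentage points lower (within the scatter) from compound 3 to compound 4, 1 percentage points apart, within the scatter of two such steps This does not show that a chloro group leaves growth inhibition untouched on any core in this series, since it rests on only two pairs, at a single concentration in a single assay, with the chloro entering at a different place in each pair; moreover, compound 1 gives only 4%, a number with little room to fall, so that pair is a weak test of whether a chloro group can lower the number.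

The compounds shown leave open whether a group other than chloro, such as a methoxy group, a nitrile or an amine, would also leave the number unchanged when set para to the large group on the phenyl ring of compound 3. They also leave open what a chloro group would do elsewhere on that ring.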